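Coumarin ether series: pyridinyl to oxadiazolyl swap

The compounds below may be only part of what the source reports. "The series", "measured", "known", "first", "only" and "open" are said of these compounds alone.

Measured so far:
compound 1 `Cc1c(C)c2ccc(OC(C)c3ccc(C(C)C)cc3)cc2oc1=O`, 10000 nM
compound 2 `Cc1c(C)c2ccc(OCc3ccccn3)cc2oc1=O`, 9 nM

In an assay on brain for inhibition of Amine oxidase [flavin-containing] B (Rattus norvegicus) (on this read-out higher numbers stand for weaker inhibition and lower numbers for stronger inhibition), compound 2 gives 9 nM. Compound 2 holds the lowest of the two numbers shown, and its nearest neighbour is compound 1, whose number in this assay is higher by a margin well beyond the scatter; no step between the two is set out, so the two values are read only side by side.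

The next compound, compound 3 `Cc1nnc(COc2ccc3c(C)c(C)c(=O)oc3c2)o1`, follows from compound 2 by 5-methyl-1,3,4-oxadiazol-2-yl in place of pyridin-2-yl on a saturated chain carbon bound to an oxygen on an aromatic ring. The change keeps the shared core and the ether link intact and exchanges the aromatic group on the chain. Nothing measured in this series bears on such an exchange, so the direction and size of the step rest on expectation alone. A modest upward step, that is a weakening, is expected in this assay, a 3.3-fold higher number from compound 2 to compound 3 (0.52 log units; beyond the scatter), with a wide band that also allows an outcome within the scatter of compound 2.

For compound 3 the expected value in this assay is 30 nM, with a range from 5 nM to 250 nM.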

Compound 3, half-maximal inhibitory concentration: 15 nM
The estimate for compound 3 lay 2.0-fold (0.30 log units) above the measured number; the measured number falls inside the stated range.
By their numbers in this assay, from the lowest: compounds 2 and 3 (each within the scatter of the next); then compound 1.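

In this assay, the exchange of pyridin-2-yl for 5-methyl-1,3,4-oxadiazol-2-yl on a saturated chain carbon bound to an oxygen on an aromatic ring gives a 1.7-fold higher number from compound 2 to compound 3 (0.22 log units; within the scatter), so the two compounds cannot be told apart on this read-out. For the compounds shown here, this is the first step read at this place, and it shows that a five-membered aromatic ring with 3 hetero atoms can stand in for a six-membered aromatic ring with 1 hetero atom without a change beyond the scatter, a statement that holds for this one pair only. No measurement of any property of the two groups accompanies this result, and nothing on record accounts for it.

Still open, as far as these compounds go, is whether the methyl on the oxadiazole ring contributes at all, which the unsubstituted 1,3,4-oxadiazol-2-yl group would test. Also open, from the compounds shown here alone, is how far the tolerance extends, for instance to a plain phenyl, a saturated ring such as piperidin-4-yl, a carboxylic acid on the chain, or a longer chain between the ether oxygen and the ring.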